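Moving the chlorine on the anilino ring of compound 1

This account rests on a few compounds, and the source may have more. Where it says the series, first, only, none or still open, it means among the compounds named here.

Measured compounds and their values:
- compound 1, `Clc1cccc(Nc2ccc(N3CC4CC(C3)N4)nn2)c1`, 1540 nM
- compound 2, `Oc1ccc(Nc2ccc(N3CC4CC(C3)N4)cn2)cc1`, 7.1 nM
- compound 3, `Cc1ccc(Nc2ccc(N3CC4CC(C3)N4)cn2)cc1`, 52.1 nM

In an assay on cell membranes for displacement of a labelled ligand from Neuronal acetylcholine receptor; alpha4/beta2 (Rattus norvegicus) (on this read-out lower numbers stand for stronger inhibition and higher numbers for weaker inhibition), compound 1 gives the highest number of the three, so it is the weakest binder among them. Its nearest neighbour is compound 3, which gives 52.1 nM in this assay, and the furthest is compound 2, which gives 7.1 nM. Compound 1 also differs from compounds 2 and 3 in the core that carries the anilino group, so its two gaps to them cannot be tied to any single change.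

Compound 4 is `Clc1ccc(Nc2ccc(N3CC4CC(C3)N4)nn2)cc1`. It keeps the core and the chlorine of compound 1, but the chlorine sits elsewhere on the ring: 4-chlorophenyl in place of 3-chlorophenyl on a nitrogen on an aromatic ring.

Within the data shown here, the only measured step, a 7.3-fold higher number from compound 2 to compound 3 (0.87 log units; beyond the scatter), swaps one group for another on an aromatic carbon and shows that the anilino ring is sensitive to what sits on it. Among the measured compounds shown here, no measured step moves a group from one ring position to another, and none touches the core of compound 1, so the step to compound 4 has no direct precedent. The value of compound 1 is high, so there is room for improvement. Compound 4 is therefore expected to bind somewhat more strongly than compound 1, with a step of a 1.9-fold lower number from compound 1 to compound 4 (0.28 log units; within the scatter), though a change within the scatter would not be surprising. The estimate for compound 4 in this assay is 800 nM, with a range from 200 nM to 3000 nM.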

Compound 4, inhibition constant: 90.4 nM
Compound 4: the middle estimate sits 8.8-fold (0.95 log units) above what was measured, outside the stated range (below it).
By their numbers in this assay, from the lowest: compound 2; then compounds 3 and 4 (each within the scatter of the next); then compound 1.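

In this assay, moving the chlorine alone gives a 17-fold lower number from compound 1 to compound 4 (1.23 log units; beyond the scatter), a large step that goes well beyond the scatter. Among these compounds, the 2>3 pair showed only that exchanging one group for another on the anilino ring can change binding, whereas 3-chlorophenyl and 4-chlorophenyl have the same heavy atoms and the same counts of hydrogen-bond donors and acceptors, so this result shows that the placement of the chlorine matters on the core of compound 1 even when the composition stays the same. Nothing available explains why the 4-chlorophenyl group gives the lower number.

As far as these compounds go, whether the gain belongs to chlorine itself remains open, and a methoxy group or an amine in place of the chlorine of the 4-chlorophenyl group in compound 4 would help to settle that question. Also open, from the compounds shown here alone, is how much of the gap between compound 4 and compounds 2 and 3 comes from the core and how much from the group on the anilino ring, since these compounds differ in more than one place.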